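The compounds below may be only part of what the source reports. "The series", "measured", "known", "first", "only" and "open" are said of these compounds alone.

Compound 1 `CC(C)n1ncc2c(C(=O)NCc3cn(-c4ccc([N+](=O)[O-])cc4)nn3)cccc21` and compound 2 `CCc1ccc(-n2cc(CNC(=O)c3cccc4c3cnn4C(C)C)nn2)cc1` share one core and differ in a single place. In a functional assay on MCF7 cells (Homo sapiens) for inhibition, read by MTT assay, with a stated time of 72 h (on this read-out lower numbers stand for stronger inhibition and higher numbers for weaker inhibition), compound 1 returns only a limit of the assay, > 40000 nM. In this assay compound 2 likewise returns only a limit, > 40000 nM. The step between them is a step that the two limits leave unreadable from compound 1 to compound 2, since both values fall on (the limit of > 40000 nM in this assay, at which 2 of the 2 values shown sit). Compound 3 `CC(C)n1ncc2c(C(=O)NCc3cn(Cc4ccc(C#N)cc4)nn3)cccc21` has not yet been measured in this assay. It differs from compound 2 by 4-cyanobenzyl in place of 4-ethylphenyl on an aromatic nitrogen. Among the measured compounds shown here, the one measured step bears on this change only as a pair of limits, and no numbered step is available to set a direction or a size. Compound 3 is therefore expected to sit near 40000 nM, within 15000 nM to 100000 nM. The step from compound 2 to compound 3 is expected to be a number no higher from compound 2 to compound 3 (the limit leaves the size open), with a further limit the most likely outcome.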

Compound 3, half-maximal inhibitory concentration: > 40000 nM
Compound 3 ended at the assay's limit; the forecaster's own chance of this, stated with the estimate: 75%; the middle value sits exactly at the limit.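

Among the compounds shown here, compound 3 ends at a limit in this assay, as do compound 1 and compound 2, so no step among the three can be read: the limit of > 40000 nM in this assay, at which 3 of the 3 values shown sit. The compounds shown leave open whether 4-cyanobenzyl, 4-ethylphenyl and 4-nitrophenyl differ at all in their effect on the read-out.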